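The source may hold more compounds than are shown below. What is called first, only, known or untested is meant among the compounds shown, and "the series" means these compounds.

Measured so far in an assay on COS-7 cells for inhibition of sodium/nucleoside cotransporter 2 (Homo sapiens), read by scintillation counting; on this read-out lower numbers stand for stronger inhibition and higher numbers for weaker inhibition:
compound 1, `CCOc1cc(CNc2nc3c(N)ncnc3n2[C@@H]2O[C@H](CO)[C@@H](O)[C@H]2O)ccc1-c1ccccc1` — 2300 nM
compound 2, `CCCOc1cc(CNc2nc3c(N)ncnc3n2[C@@H]2O[C@H](CO)[C@@H](O)[C@H]2O)ccc1-c1ccccc1` — 5200 nM

Compound 2 holds the higher of the two numbers seen so far in this assay, so it is the weaker of the pair on this read-out. For the measured compounds named here, the single one-place step between them, a 2.3-fold higher number from compound 1 to compound 2 (0.35 log units; beyond the scatter), is modest but beyond the scatter.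

Compound 3, `CC(C)Oc1cc(CNc2nc3c(N)ncnc3n2[C@@H]2O[C@H](CO)[C@@H](O)[C@H]2O)ccc1-c1ccccc1`, is the next to be measured in this assay. It differs from compound 2 by isopropyl in place of propyl on an oxygen on an aromatic ring; the two have the same atoms, joined differently, and the difference cut one bond further out reads propoxy to isopropoxy.

Going by the values given here, the only measured step, a 2.3-fold higher number from compound 1 to compound 2 (0.35 log units; beyond the scatter), concerns adding a methyl to lengthen the chain, not rearranging it; it bears on the present change only loosely. Among the compounds with values here, no step shows what branching the chain does in this assay. For compound 3 the expected step is therefore a 1.0-fold lower number from compound 2 to compound 3 (0.02 log units; within the scatter), essentially none beyond the scatter, with a wide range to reflect the missing evidence. Compound 3 is estimated at 5000 nM, within 2000 nM to 13000 nM.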

Compound 3, half-maximal inhibitory concentration: 10400 nM
Estimate against measurement, compound 3: 2.1-fold (0.32 log units) below, within the range that was stated.
By their numbers in this assay, from the lowest: compound 1; then compounds 2 and 3 (each within the scatter of the next).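

In this assay the rearrangement of propyl to isopropyl on the oxygen on the aromatic ring gives a 2.0-fold higher number from compound 2 to compound 3 (0.30 log units; within the scatter) and so does not separate the two chains at this position. The methyl on the saturated chain carbon bound to that oxygen gives a 4.5-fold higher number from compound 1 to compound 3 (0.66 log units; beyond the scatter) and the methyl further along the chain gives a 2.3-fold higher number from compound 1 to compound 2 (0.35 log units; beyond the scatter) so both additions to compound 1 raise the number beyond the scatter, whichever carbon carries the methyl. No measurement at hand accounts for these steps.

Open, on these data alone, is how a longer chain such as butyl, or a tert-butyl or cyclopropyl group, reads on the same oxygen. Also open, as far as these compounds go, is whether a methyl on that oxygen, or a free hydroxyl in place of the whole alkoxy group, gives a lower number than compound 1.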